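A Methoxy Removal Tested Against Glioblastoma Cells

The source may hold more compounds than are shown below. What is called first, only, known or untested is meant among the compounds shown, and "the series" means these compounds.

Of the compounds shown here, three have been measured in a functional assay on U-87MG ATCC cells for antiproliferative activity against U-87 MG (Homo sapiens), read by MTT assay, with a stated time of 48 h, tested at 100 uM; a higher number here means a weaker effect of the compound at the concentration tested, a lower number a stronger effect. In this assay compound 1 `COc1ccc(-c2nc(C)c(C(=O)CSc3nc(N)c(C#N)c(-c4ccc(Cl)cc4)n3)s2)cc1` gives 3.9%, the lowest of the three numbers, although its distance to the other two stays within the usual scatter of repeated measurements. Compound 2 `COc1ccc(-c2nc(C)c(C(=O)CSc3nc(-c4ccc(OC)cc4)c(C#N)c(=O)[nH]3)s2)cc1` gives 11.5% in this assay, and compound 3 `COc1ccc(-c2nc(C)c(C(=O)CSc3nc(-c4ccc(OC)c(OC)c4)c(C#N)c(=O)[nH]3)s2)cc1` gives 5.39%. Compound 3 and compound 2 differ in one place, (hydrogen in place of methoxy on an aromatic carbon), and that change made a step of a number 6.1 percentage points higher from compound 3 to compound 2 (within the scatter). Compound 1 and compound 3 differ in more than one place; the difference between the two cores is not broken down here.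

Compound 4 `Cc1nc(-c2ccccc2)sc1C(=O)CSc1nc(N)c(C#N)c(-c2ccc(Cl)cc2)n1` has not yet been measured. It differs from compound 1 by hydrogen in place of methoxy on an aromatic carbon. Among the measured compounds shown here, this is the same kind of change as the one from compound 3 to compound 2, but not the same: in compound 1 the methoxy that leaves sits para to a large group, whereas in compound 3 it sits ortho to a methoxy group and meta to a large group. Because a number 6.1 percentage points higher from compound 3 to compound 2 (within the scatter) stayed within the scatter, a step of similar size is expected from compound 1 to compound 4, namely a number 4.1 percentage points higher from compound 1 to compound 4 (within the scatter). Compound 4 is therefore estimated to give about 8% in this assay. The expectation for compound 4 is taken to span from 2% to 22%.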

Compound 4, a percentage reported as activity, at one concentration (the size of the read-out at that concentration, not a potency): 17.1%
Estimate against measurement, compound 4: 9.1 percentage points below; the range from low to high includes it.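

In this assay, the change from 4-methoxyphenyl to phenyl gave a number 13.2 percentage points higher from compound 1 to compound 4 (beyond the scatter), so on this core, losing the methoxy left a weaker effect at the concentration tested. Set beside the earlier case, the two steps cannot be told apart: the same change on two cores in this assay, a number 6.1 percentage points higher (within the scatter) from compound 3 to compound 2 and a number 13.2 percentage points higher (beyond the scatter) from compound 1 to compound 4, 7.1 percentage points apart, within the scatter of two such steps. Among the compounds shown here, the data thus give no sign that the core alters what this change does, but they do not prove that it carries over unchanged: only one of the two steps stands clear of the scatter, the methoxy leaves a different place in each pair, and each number is a read-out at one concentration rather than a potency.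

The compounds shown leave open what a hydroxyl, an amine or a carboxylic acid would do in place of the methoxy on this aromatic ring, on either core. They also leave open how the two cores themselves compare, as compounds on different cores here differ in more than one place and the contribution of the core alone cannot be separated out.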